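Adding 4-fluorophenyl at the ring amide nitrogen

The compounds below may be only part of what the source reports. "The series", "measured", "known", "first", "only" and "open" are said of these compounds alone.

Going by the values given here, in a functional assay on A-375 cells (Homo sapiens) for antiproliferative activity, read by MTT assay, with a stated time of 72 h (on this read-out lower numbers stand for stronger inhibition and higher numbers for weaker inhibition), compound 1 `O=C1COc2ccc(-c3cccc(NS(=O)(=O)c4ccc(F)cc4)c3)cc2N1` gives 20100 nM and sets one of only two numbers available in this small series.

Compound 2 `COc1ccc(N2C(=O)COc3ccc(-c4ccc(O)cc4)cc32)cc1` returns no number, only a limit of the assay at > 40000 nM.

Compound 3 `COc1ncc(-c2ccc3c(c2)NC(=O)CO3)cc1NS(=O)(=O)c1ccc(F)cc1` gives 26300 nM in this assay. Among the compounds with values here, this value lies within the scatter of the one for compound 1, so the two cannot be told apart, and both show only weak antiproliferative activity on this read-out.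

Compound 4 `COc1ncc(-c2ccc3c(c2)N(c2ccc(F)cc2)C(=O)CO3)cc1NS(=O)(=O)c1ccc(F)cc1` has not yet been measured. It is compound 3 with one change: 4-fluorophenyl in place of hydrogen on an amide-type nitrogen in a ring. In words, a 4-fluorophenyl stands in place of hydrogen on an amide-type nitrogen in a ring, three ring bonds from the ring oxygen.

Within the data shown here, no pair of measured compounds shows a step of this kind, and the expectation therefore remains uncertain. A modest gain in inhibition is anticipated, only slightly beyond the scatter, though a result close to compound 3 or weaker would not be surprising.

The expected change is a 2.2-fold lower number from compound 3 to compound 4 (0.34 log units; beyond the scatter) in this assay.

Compound 4 is estimated at 12000 nM, with an expected range from 3000 nM to 40000 nM.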

Compound 4, half-maximal inhibitory concentration: > 40000 nM
Compound 4 ended at the assay's limit; the forecaster's own chance of this, stated with the estimate: 20%; at least 3.3-fold (0.52 log units) between middle value and limit.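

Going by these compounds alone, the step gives the first reading at this position, the amide-type nitrogen in a ring, three ring bonds from the ring oxygen: in this assay, there is an at least 1.5-fold higher number from compound 3 to compound 4 (0.18 log units; that floor lies within the scatter). That figure is only a floor and lies within the scatter, so it does not establish a loss of activity, but it does show that 4-fluorophenyl in place of hydrogen here brought none of the stronger inhibition that a lower number would have meant. The true size of the step cannot be read, since the result for compound 4 is a limit and not a number, and the read-out gives no graded value at that end of the scale: the limit of > 40000 nM in this assay, at which 2 of the 4 values shown sit.

The compounds shown leave open whether a much smaller group on this nitrogen, such as methyl, or a chain carrying an amine, such as 2-aminoethyl, would give a number that can be read against compound 3. They also leave open whether 4-fluorophenyl at this nitrogen would behave in the same way on the core of compound 1.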